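A few compounds are considered here, and "the series" means these few. Any claim that something is new, unique, unknown or untested is made for them only; others in the source may bear on it.

Measured so far in a functional assay on RKO cells (Homo sapiens) for inhibition, read by MTT assay, with a stated time of 48 h; on this read-out higher numbers stand for weaker inhibition and lower numbers for stronger inhibition: compound 1 `COc1ccc(N(C)c2nc(C)nc3ccccc23)cc1C(=O)OCCCCC[Se]C#N` gives 356 nM; compound 2 `COc1ccc(N(C)c2nc(C)nc3ccccc23)cc1C(=O)OCC[Se]C#N` gives 2390 nM.

Among the measured compounds shown here, compound 2 carries the higher of the two numbers, and the single measured step is a 6.7-fold higher number from compound 1 to compound 2 (0.83 log units; beyond the scatter). Compound 3 `COc1ccc(N(C)c2nc(C)nc3ccccc23)cc1[Se]C#N` differs from compound 2 by a group of 3 heavy atoms (1 carbon, 1 nitrogen, 1 selenium; no ring) in place of a group of 8 heavy atoms (4 carbon, 1 nitrogen, 2 oxygen, 1 selenium; no ring), on an aromatic carbon. That one step bears on this change, and it ran toward weaker inhibition as the chain grew shorter; the group leaving here is larger and of a different kind, so the bearing is loose. A further rise in this assay is therefore expected, a 2.1-fold higher number from compound 2 to compound 3 (0.32 log units; beyond the scatter). Compound 3 is estimated at 5000 nM, within 1000 nM to 25000 nM.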

Compound 3, half-maximal inhibitory concentration: 47 nM
Compound 3: middle estimate off by 110-fold (2.03 log units), on the high side; the whole stated range lies above it.
By their numbers in this assay, from the lowest: compound 3; then compound 1; then compound 2.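

In this assay, setting the group of 3 heavy atoms directly on the aromatic carbon in place of the group of 8 heavy atoms gives a 51-fold lower number from compound 2 to compound 3 (1.71 log units; beyond the scatter), the opposite direction to the earlier chain shortening. The trend seen along the chain therefore does not carry over to a change that removes the ester, and this position does not need that chain for a low number. Nothing available here explains this reversal.

The compounds shown leave open how an amide in place of the ester would read. They also leave open whether a single methylene spacer between the ring and selenium would keep the low number of compound 3.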